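Replacing phenoxy on a nucleoside core: tolerance on liver cells

A few compounds are considered here, and "the series" means these few. Any claim that something is new, unique, unknown or untested is made for them only; others in the source may bear on it.

Measured compounds:
compound 1, `OC[C@H]1O[C@@H](n2cnc3c(COc4ccccc4)ncnc32)[C@H](O)[C@@H]1O`, gives > 100000 nM in a functional assay on Huh-7 cells (Homo sapiens) for cytotoxicity, read by MTT assay, with a stated time of 3 days; a higher number here means that more compound is tolerated, a lower number that less compound is tolerated; this value is a limit of the assay, not a number.
compound 2, `OC[C@H]1O[C@@H](n2cnc3c(CSCc4ccccc4)ncnc32)[C@H](O)[C@@H]1O`, gives > 100000 nM in this assay ; this too is a limit of the assay.
compound 3, `CN(Cc1ccccc1)Cc1ncnc2c1ncn2[C@@H]1O[C@H](CO)[C@@H](O)[C@H]1O`, gives 9000 nM in this assay .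

Compound 1 therefore stands at the top of what this assay can read, and it shares that position with the limit of > 100000 nM in this assay, at which 2 of the 3 values shown sit. Compound 4, `O=c1ccccn1Cc1ncnc2c1ncn2[C@@H]1O[C@H](CO)[C@@H](O)[C@H]1O`, differs from compound 1 by a group of 7 heavy atoms (5 carbon, 1 nitrogen, 1 oxygen; one six-membered aromatic ring with 1 hetero atom) in place of a group of 7 heavy atoms (6 carbon, 1 oxygen; one six-membered aromatic ring of carbon only), on a saturated chain carbon bound to an aromatic carbon. Going by the values given here, none of the measured steps introduces this entering group. The steps that are readable, an at least 11-fold lower number from compound 1 to compound 3 (1.04 log units; beyond the scatter) and an at least 11-fold lower number from compound 2 to compound 3 (1.04 log units; beyond the scatter), both run toward benzyl(methyl)amino and both lower the tolerated concentration by a large amount, while a step that the two limits leave unreadable from compound 1 to compound 2 cannot be read since both ends sit at the limit. Among the compounds with values here, compound 4 carries no benzyl(methyl)amino, so no measured step points to a fall of that kind for it. The expected step is therefore one within the scatter, a number no higher from compound 1 to compound 4 (the limit leaves the size open). Compound 4 is estimated at 100000 nM, with a range from 30000 nM to 300000 nM, and the assay is expected most likely to report a limit again.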

Compound 4, half-maximal cytotoxic concentration: > 100000 nM
Compound 4: no number, only a limit; the forecaster's own chance of this, stated with the estimate: 70%; the middle value lies on the limit itself.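

In this assay, the saturated chain carbon bound to an aromatic carbon now carries a third group that leaves the read-out at a limit of the assay, so this position at the top of the range is not confined to phenoxy and benzylsulfanyl: the limit of > 100000 nM in this assay, at which 3 of the 4 values shown sit.

Going by these compounds alone, the one new step that can be read is an at least 11-fold higher number from compound 3 to compound 4 (1.04 log units; beyond the scatter), which shows that a nitrogen in the group on this carbon does not by itself bring the number down, since both groups contain one and compound 3 alone has a readable value among the four. The steps from compound 1 to compound 4 and from compound 2 to compound 4 cannot be read, as both ends of each are limits.

As far as these compounds go, how far compound 1, compound 2 and compound 4 lie beyond the limit stays unknown, so no order can be given among them. Also open, from the compounds shown here alone, is whether the lower number of compound 3 needs the benzyl group, or whether a smaller amine such as dimethylamino on the same carbon would also lower the tolerated concentration.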